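The source may hold more compounds than are shown below. What is called first, only, known or untested is meant among the compounds shown, and "the series" means these compounds.

Within the data shown here, in a functional assay on RAW264.7 cells (Mus musculus) for inhibition, read by Griess assay, with stated times of 1 h and 24 h (on this read-out lower numbers stand for stronger inhibition and higher numbers for weaker inhibition), compound 3 `COCCCCOc1ccc(C(O)C2OC(=O)c3c(OC)cc(OC)cc32)cc1` gives 8210 nM, the only true number among the values shown so far. Compound 1 `O=C1OC(Cc2nc(-c3ccccc3)no2)c2ccccc21` reaches only a limit, > 10000 nM. Compound 2 `O=C1OC(Cc2nc(-c3ccc(Oc4ccccc4)cc3)no2)c2ccccc21` also reaches only a limit, > 10000 nM. This leaves little to compare, as the limit of > 10000 nM in this assay, at which 2 of the 3 values shown sit, makes plain.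

The next compound, compound 4 `COc1cc(OC)c2c(c1)C(C(O)c1ccc(OCc3ccc(Br)cc3)cc1)OC2=O`, keeps the core of compound 3 and changes the end of the chain: 4-bromophenyl in place of 3-methoxypropyl on a saturated chain carbon bound to an oxygen on an aromatic ring. Put another way, 4-methoxybutoxy gives way to (4-bromobenzyl)oxy, and a ring enters where compound 3 has none.

Among the measured compounds shown here, only one measured step comes near this change: a step that the two limits leave unreadable from compound 1 to compound 2. It also adds an aromatic ring, as phenoxy in place of hydrogen on an aromatic carbon, but it does so on the core of compound 1 rather than that of compound 3, and it has no readable size. It therefore offers no size or direction to carry over, and no shift beyond the usual scatter in this assay is expected. The expected change is a 1.4-fold lower number from compound 3 to compound 4 (0.14 log units; within the scatter), which is a weak expectation with no firm direction. For compound 4 the estimated value is 6000 nM, with an expected range from 1500 nM to 20000 nM, and a result reported only as a limit would not be surprising.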

Compound 4, half-maximal inhibitory concentration: 6530 nM
For compound 4 the middle estimate is 1.1-fold (0.04 log units) below the measured one; the range from low to high includes it.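

Among these compounds, at the end of the chain on the shared core, 4-bromophenyl in place of 3-methoxypropyl gives a 1.3-fold lower number from compound 3 to compound 4 (0.10 log units; within the scatter) in this assay, the first step that can be read at all. On a saturated chain carbon bound to an oxygen on an aromatic ring, an open chain and a chain ending in a six-membered aromatic ring with bromine thus stay within the usual scatter of each other. The only earlier step, which stands on the core of compound 1, cannot be read, and the limit still marks much of what is shown: the limit of > 10000 nM in this assay, at which 2 of the 4 values shown sit.

Going by these compounds, it remains open whether any group at this place can move the number beyond the scatter, for instance an amine or a carboxylic acid at the end of the chain, a longer chain, or plain benzyl in place of 4-bromobenzyl. Also open, on these data alone, is what the hydroxyl and the two methoxy groups contribute, as both compounds on this core carry them.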